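This account rests on a few compounds, and the source may have more. Where it says the series, first, only, none or still open, it means among the compounds named here.

Measured compounds:
compound 1, `O=C(Nc1cccc(OCc2cn(-c3ccccc3)nn2)c1)Nc1ccc(Cl)c(C(F)(F)F)c1`, 1780 nM
compound 2, `Cc1ccccc1-n1cc(COc2cccc(NC(=O)Nc3ccc(Cl)c(C(F)(F)F)c3)c2)nn1`, 3440 nM
compound 3, `CCc1cccc(-n2cc(COc3cccc(NC(=O)Nc4ccc(Cl)c(C(F)(F)F)c4)c3)nn2)c1`, 37900 nM

In a functional assay on HepG2 cells (Homo sapiens) for inhibition, read by MTT assay, with a stated time of 72 h (on this read-out lower numbers stand for stronger inhibition and higher numbers for weaker inhibition), compound 3 stands highest of the three, its number lying beyond the scatter from both compound 2 and compound 1. Compound 4, `O=C(Nc1cccc(OCc2cn(-c3ccccc3F)nn2)c1)Nc1ccc(Cl)c(C(F)(F)F)c1`, differs from compound 3 by 2-fluorophenyl in place of 3-ethylphenyl on an aromatic nitrogen. Going by the values given here, two measured steps bear on this position: a 21-fold higher number from compound 1 to compound 3 (1.33 log units; beyond the scatter), and an 11-fold higher number from compound 2 to compound 3 (1.04 log units; beyond the scatter), whereas a 1.9-fold higher number from compound 1 to compound 2 (0.29 log units; within the scatter). Those steps show that the 3-ethylphenyl on the aromatic nitrogen goes with a far higher number, while the phenyl of compound 1 and the 2-methylphenyl of compound 2 give numbers close to each other. Replacing the 3-ethylphenyl is therefore expected to bring the number back down in this assay, so compound 4 is expected to show a 15-fold lower number from compound 3 to compound 4 (1.18 log units; beyond the scatter). The estimate for compound 4 is 2500 nM, with a range from 1000 nM to 7000 nM.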

Compound 4, half-maximal inhibitory concentration: 1520 nM
Compound 4: the middle estimate sits 1.6-fold (0.22 log units) above what was measured; the range from low to high includes it.
By their numbers in this assay, from the lowest: compounds 4, 1 and 2 (each within the scatter of the next, the first and the last beyond it); then compound 3.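

2-fluorophenyl in place of 3-ethylphenyl gives a 25-fold lower number from compound 3 to compound 4 (1.40 log units; beyond the scatter) in this assay, so a group on this phenyl ring does not by itself go with a high number. Fluoro in place of hydrogen gives a 1.2-fold lower number from compound 1 to compound 4 (0.07 log units; within the scatter) and leaves these two compounds indistinguishable, while fluoro in place of methyl gives a 2.3-fold lower number from compound 2 to compound 4 (0.35 log units; beyond the scatter) as a modest step. Nothing measured here explains these differences. On these data alone, whether the ethyl group itself or its place on the ring sets compound 3 apart stays open, as does how a methoxy group, an amine or a carboxylic acid on this ring would read.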